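Aryl swap on the carbonyl carbon of the shared core

The compounds below may be only part of what the source reports. "The series", "measured", "known", "first", "only" and "open" are said of these compounds alone.

Compound 1 `COc1ccc(/C=C/c2cc(OC)cc(OC)c2/C=C/C(=O)c2ccc(Cl)c(Cl)c2)cc1` and compound 2 `CCCCOc1ccc(C(=O)/C=C/c2c(/C=C/c3ccc(OC)cc3)cc(OC)cc2OC)cc1` share a core and differ only in the aryl group on the carbonyl carbon. In a functional assay on B16-F10 cells (Mus musculus) for antiproliferative activity, read by MTT assay, with a stated time of 48 h (on this read-out higher numbers stand for weaker inhibition and lower numbers for stronger inhibition), compound 1 gives 7.5 ug/mL, the highest of the two numbers; compound 2 gives 5.3 ug/mL. Going by the values given here, the one measured step, a 1.4-fold lower number from compound 1 to compound 2 (0.15 log units; within the scatter), is within the scatter, so the aryl group on the carbonyl carbon has so far not moved the read-out.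

Compound 3 `COc1ccc(/C=C/c2cc(OC)cc(OC)c2/C=C/C(=O)c2cccc(Br)c2)cc1` is not yet measured. It differs from compound 1 in the same place: 3-bromophenyl in place of 3,4-dichlorophenyl on a carbonyl carbon. The step from compound 1 to compound 2 is the only one that bears on this change, and it was within the scatter. No step beyond the scatter is therefore expected in this assay; the estimated step from compound 1 to compound 3 is a 1.1-fold lower number from compound 1 to compound 3 (0.03 log units; within the scatter). Compound 3 is expected to give 7 ug/mL, with a range from 3.5 ug/mL to 14 ug/mL.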

Compound 3, half-maximal inhibitory concentration: 5.1 ug/mL
The estimate for compound 3 lay 1.4-fold (0.14 log units) above the measured number; low and high end bracket the measured number.
By their numbers in this assay, from the lowest: compounds 3, 2 and 1 (each within the scatter of the next).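

The swap to 3-bromophenyl on the carbonyl carbon gives a 1.5-fold lower number from compound 1 to compound 3 (0.17 log units; within the scatter) in this assay and, measured against the other aryl group, a 1.0-fold lower number from compound 2 to compound 3 (0.02 log units; within the scatter) on the same read-out. Going by these compounds alone, the position now holds three aryl groups, 3,4-dichlorophenyl, 4-butoxyphenyl and 3-bromophenyl, and no pair of them is separated beyond the scatter, so the flat result no longer rests on a single step. No available data explain why these three groups read alike.

The compounds shown leave open whether this flat reading extends to an aryl group carrying an amine or a carboxylic acid, or to a simple alkyl chain on the carbonyl carbon. They also leave open how changes elsewhere on the shared core would read in this assay.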